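The compounds below may be only part of what the source reports. "The series", "measured", "known", "first", "only" and "open" are said of these compounds alone.

Measured compounds in an assay on isolated protein for binding affinity to prostaglandin E2 receptor EP1 subtype (Homo sapiens); on this read-out lower numbers stand for stronger inhibition and higher numbers for weaker inhibition:
- compound 1, `CCCCC1([C@H](O)/C=C/[C@H]2COC(=O)N2CCSc2nc(C(=O)O)cs2)CCC1`: 220 nM
- compound 2, `O=C(O)c1csc(SCCN2C(=O)OC[C@@H]2/C=C/[C@@H](O)C2(CCc3ccccc3)CCC2)n1`: 802 nM
- compound 3, `CCOCCC1([C@H](O)/C=C/[C@H]2COC(=O)N2CCSc2nc(C(=O)O)cs2)CCC1`: 8420 nM

Compound 2 stands second highest of the three numbers in this assay; compound 1 lies nearest, with a 3.6-fold higher number from compound 1 to compound 2 (0.56 log units; beyond the scatter), and compound 3 furthest, with a 10-fold higher number from compound 2 to compound 3 (1.02 log units; beyond the scatter).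

Compound 4, `COCCCC1([C@H](O)/C=C/[C@H]2COC(=O)N2CCSc2nc(C(=O)O)cs2)CCC1`, has not been measured. It differs from compound 2 in one place: methoxymethyl in place of phenyl on a saturated chain carbon, two bonds along the chain from a saturated ring carbon.

For the measured compounds named here, two measured steps bear on this. The closest is the step from compound 2 to compound 3, which also puts an ether oxygen on the chain at the cost of the phenyl and gave a 10-fold higher number from compound 2 to compound 3 (1.02 log units; beyond the scatter). The step from compound 1 to compound 3 points the same way, with a 38-fold higher number from compound 1 to compound 3 (1.58 log units; beyond the scatter). Both ether-bearing changes raised the number by a large margin, so a large rise beyond the scatter is expected for compound 4 as well, and the estimated step is a 6.2-fold higher number from compound 2 to compound 4 (0.79 log units; beyond the scatter).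

Compound 4 is therefore estimated at 5000 nM in this assay, with a range of 1500 nM to 15000 nM.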

Compound 4, inhibition constant: > 10000 nM
Compound 4 was reported as a limit; the forecaster's own chance of this, stated with the estimate: 5%; at least 2.0-fold (0.30 log units) between middle value and limit.
By their numbers in this assay, from the lowest: compound 1; then compound 2; then compound 3. At a limit, above all of these: compound 4.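

Compound 4 is reported only as a limit: the limit of > 10000 nM in this assay, at which 1 of the 4 values shown sits. Methoxy in place of methyl on a saturated chain carbon, three bonds along the chain from a saturated ring carbon, gives an at least 45-fold higher number from compound 1 to compound 4 (1.65 log units; beyond the scatter), and methoxymethyl in place of phenyl gives an at least 12-fold higher number from compound 2 to compound 4 (1.09 log units; beyond the scatter), so the large rise at this position does not rest on the ethoxy chain of compound 3 alone. Methoxymethyl in place of ethoxy gives an at least 1.1-fold higher number from compound 3 to compound 4 (0.07 log units; that floor lies within the scatter), a floor within the scatter, so the two ether-bearing chains cannot be put in order.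

Open, on these data alone, is whether a longer all-carbon chain stays close to compound 1 in this assay. Also open, as far as these compounds go, is whether an amine or a hydroxyl at the chain end behaves like the two ethers.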